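This account rests on a few compounds, and the source may have more. Where it says the series, first, only, none or still open, it means among the compounds named here.

Three compounds of the series have numbers in an ADME assay on 184B5 cells (Homo sapiens) for cytotoxicity, read by MTT assay, with a stated time of 72 h; on this read-out lower numbers stand for stronger inhibition of growth and higher numbers for weaker inhibition of growth. Compound 1, `CC(C)COC(=O)Nc1ccc([Se][Se]c2ccc(NC(=O)OCC(C)C)cc2)cc1`, gives 10500 nM in this assay. Compound 2, `N#C[Se]c1ccc(NC(=O)Oc2ccc(F)cc2)cc1`, gives 29500 nM in this assay. Compound 3, `C=CCOC(=O)Nc1ccc([Se]C#N)cc1`, gives 9800 nM in this assay, the lowest of the three numbers; its gap to compound 1 lies within the scatter, so no order between those two can be read, while its gap to compound 2 lies beyond the scatter. For the measured compounds named here, no two of the three measured compounds differ in a single place, so no step between measured compounds is available to lean on.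

Compound 4, `CCCOC(=O)Nc1ccc([Se]C#N)cc1`, has not yet been measured in this assay. It differs from compound 3 in one place: ethyl in place of vinyl on a saturated chain carbon bound to an oxygen next to a carbonyl group. The change is small: a double bond outside aromatic rings is lost, the group that enters is otherwise the same size, and no donor or acceptor changes. Going by the values given here, none of the measured compounds probes a change of this kind, and the series gives no ground for a shift in either direction. The step of a 1.0-fold higher number from compound 3 to compound 4 (0.01 log units; within the scatter) is therefore expected to stay within the scatter. Compound 4 is estimated to give 10000 nM in this assay, with a range from 5000 nM to 20000 nM.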

Compound 4, concentration for total growth inhibition: 9100 nM
Compound 4: the middle estimate sits 1.1-fold (0.04 log units) above what was measured; the range from low to high includes it.
By their numbers in this assay, from the lowest: compounds 4, 3 and 1 (each within the scatter of the next); then compound 2.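

In this assay, the series now has its first step between compounds that differ in one place: ethyl in place of vinyl on a saturated chain carbon bound to an oxygen next to a carbonyl group gives a 1.1-fold lower number from compound 3 to compound 4 (0.03 log units; within the scatter). Read as allyl to propyl, this means that, for this pair, the double bond outside aromatic rings can be lost from this position without a readable shift in the number, and a saturated chain of the same size serves as well as the unsaturated one. No outside measurement bears on this result, so the step stands as an observation alone.

Going by these compounds, what happens at this position with a longer chain such as octyl, or with a chain carrying an amine or a carboxylic acid, remains open, since a change of equal size says nothing about a change in length or in the atoms present. Also open, on these data alone, is whether allyl to propyl reads the same on the core of compound 1 or alongside other changes, as this single pair covers only the core of compound 3.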